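Methoxyphenyl for Fluorophenyl on a Near-Inactive Triazine

The source may report more compounds than this note shows. Statements on the series, on what has been measured and on what is new or still open speak of the compounds shown alone.

Within the data shown here, compound 1 `N#Cc1ccc(Nc2nc(Oc3ccnc4ccccc34)nc(N3CCCCC3)n2)cc1C(F)(F)F` gives the only number in this set. In a functional assay on DU-145 cells (Homo sapiens) for cytotoxicity, read by sulforhodamine B assay, with a stated time of 48 h (a higher number here means a weaker inhibitor of growth, a lower number a stronger inhibitor of growth), compound 1 gives 94900 nM. Compound 2 `N#Cc1ccc(Nc2nc(Oc3ccnc4ccccc34)nc(N3CCN(c4ccccc4F)CC3)n2)cc1C(F)(F)F` carries a 2-fluorophenyl on the amine nitrogen in the ring. In this assay compound 2 returns only a limit, > 100000 nM, so no number is known for it. That is where compound 2 stands: at the limit of > 100000 nM in this assay, at which 1 of the 2 values shown sits. Among the measured compounds shown here, of the pair, the two values show only that compound 1 has a number at the weak end of what this assay can resolve and that compound 2 sits on the limit itself, so no step can be taken from one to the other.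

Compound 3 `COc1ccc(N2CCN(c3nc(Nc4ccc(C#N)c(C(F)(F)F)c4)nc(Oc4ccnc5ccccc45)n3)CC2)cc1` is the unmeasured one. It differs from compound 2 in one place: 4-methoxyphenyl in place of 2-fluorophenyl on an amine nitrogen in a ring.

For the measured compounds named here, no measured step accompanies this change, so the step of a number no higher from compound 2 to compound 3 (the limit leaves the size open) is expected to be none beyond the usual scatter, and compound 3 is most likely to return a limit again rather than a number. Compound 3 is estimated at 100000 nM, with a range from 40000 nM to 250000 nM.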

Compound 3, concentration for 50% growth inhibition: > 100000 nM
Compound 3: no number, only a limit (the forecaster's own chance of this, stated with the estimate: 60%); the middle value sits exactly at the limit.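

In this assay compound 3 gives > 100000 nM, which is a limit and not a number. Compound 2 also gives only a limit, so no step can be read from compound 2 to compound 3. The compounds shown leave open whether 4-methoxyphenyl and 2-fluorophenyl on the amine nitrogen in the ring differ at all in this assay: the limit of > 100000 nM in this assay, at which 2 of the 3 values shown sit.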